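This account rests on a few compounds, and the source may have more. Where it says the series, first, only, none or still open, it means among the compounds named here.

In a functional assay, read by spectrophotometry, with a stated time of 30 min (on this read-out lower numbers stand for stronger inhibition and higher numbers for weaker inhibition), compound 1 `Cc1ccc2[nH]c(=O)c(/C=N/c3ccc(O)cc3)cc2c1` gives 88500 nM, compound 2 `O=c1[nH]c2ccccc2cc1/C=N/c1ccc(O)cc1` gives 92100 nM and compound 3 `Cc1ccc2[nH]c(=O)c(/C=N/Nc3ccccc3)cc2c1` gives 62400 nM. Compound 2 therefore stands within the scatter of both other compounds, and the three form a single narrow group of numbers. Compound 4 `NS(=O)(=O)c1ccc(/N=C/c2cc3ccccc3[nH]c2=O)cc1` has sulfamoyl in place of hydroxy on an aromatic carbon, para to a large group, when set against compound 2: sulfamoyl in place of hydroxy on an aromatic carbon.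

Among the compounds with values here, two measured steps bear on this change. The removal of the methyl gives a 1.0-fold higher number from compound 1 to compound 2 (0.02 log units; within the scatter), but it lies elsewhere in the structure. The replacement of 4-hydroxyphenyl by anilino gives a 1.4-fold lower number from compound 1 to compound 3 (0.15 log units; within the scatter), and it is closer to the change but still does not test sulfamoyl. Both stay within the scatter, so they offer no reason to expect a large step in this assay, although the data say nothing directly about sulfamoyl. The expected change is a 1.5-fold lower number from compound 2 to compound 4 (0.19 log units; within the scatter), a small move towards a lower number that is not expected to clearly exceed the scatter. For compound 4 the estimated value is 60000 nM, with an expected range from 10000 nM to 130000 nM.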

Compound 4, half-maximal inhibitory concentration: 266000 nM
Compound 4: middle estimate off by 4.4-fold (0.65 log units), on the low side, outside the stated range (above it).
By their numbers in this assay, from the lowest: compounds 3, 1 and 2 (each within the scatter of the next); then compound 4.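

In this assay, sulfamoyl in place of hydroxy on an aromatic carbon, para to a large group, gives a 2.9-fold higher number from compound 2 to compound 4 (0.46 log units; beyond the scatter) and is the first single change shown that goes beyond the scatter. Within the data shown here, the earlier steps, a 1.0-fold higher number from compound 1 to compound 2 (0.02 log units; within the scatter) and a 1.4-fold lower number from compound 1 to compound 3 (0.15 log units; within the scatter), stayed within it, so only this change shows that the number responds to what sits at this place, here towards weaker inhibition. Nothing measured here accounts for this step.

The compounds shown leave open how a carboxylic acid or an amine at the same place would read in this assay. They also leave open whether sulfamoyl would give a step of similar size on the core of compound 1, which carries the methyl.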